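Benzoyl anilide series: expectation for compound 4

This account rests on a few compounds, and the source may have more. Where it says the series, first, only, none or still open, it means among the compounds named here.

Three compounds of the series have been run in a functional assay (Cavia porcellus) with sulfonylurea receptors; K-ATP channels (Homo sapiens) as the target; on this read-out higher numbers stand for weaker inhibition and lower numbers for stronger inhibition. Compound 1 `CC(O)(C(=O)Nc1ccc(S(=O)(=O)c2cccc(C(F)(F)F)c2)cc1)C(F)(F)F` gives > 30000 nM, which is a limit of the assay and not a number; (the limit of > 30000 nM in this assay, at which 1 of the 3 values shown sits). Compound 2 `CC(O)(C(=O)Nc1ccc(S(=O)(=O)c2ccccc2)cc1[N+](=O)[O-])C(F)(F)F` gives 7900 nM in this assay. Compound 3 `CC(O)(C(=O)Nc1ccc(C(=O)c2ccccc2F)cc1)C(F)(F)F` gives 2300 nM in this assay, the lowest of the two numbers, and compound 2 sits beyond the scatter higher. Compound 4 `Cc1cccc(C(=O)c2ccc(NC(=O)C(C)(O)C(F)(F)F)cc2)c1` is not yet measured. It differs from compound 3 by 3-methylphenyl in place of 2-fluorophenyl on a carbonyl carbon. For the measured compounds named here, no step between two measured compounds is available, so the size of this step has no anchor in a measured pair; the change stays within one aryl ring on the carbonyl carbon, and the expectation is a step of no more than the scatter, in no fixed direction. In this assay compound 4 is expected to give 3000 nM, with a range from 1000 nM to 10000 nM. The expected step is a 1.3-fold higher number from compound 3 to compound 4 (0.12 log units; within the scatter).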

Compound 4, half-maximal inhibitory concentration: > 30000 nM
Compound 4: a limit, no number; the forecaster's own chance of this, stated with the estimate: 5%; middle value at least 10-fold (1.00 log units) from the limit.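

In this assay, this position on the carbonyl carbon proves sensitive: 3-methylphenyl in place of 2-fluorophenyl gives an at least 13-fold higher number from compound 3 to compound 4 (1.11 log units; beyond the scatter). The two groups match in heavy atoms, ring type, hydrogen-bond donors and acceptors, and net charge as counted, so these counts do not predict the size of this step. Compound 4 stands at a limit of the assay, not at a number: the limit of > 30000 nM in this assay, at which 2 of the 4 values shown sit.

The change removes the fluorine and adds the methyl in a single step, so the compounds shown do not say which of the two carries the loss, and unsubstituted phenyl on this carbonyl carbon would be the direct test. As far as these compounds go, how a ring bearing a methoxy group, an amine or a carboxylic acid would read out also stays open.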